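Removing the tetrazole from a hydroxystearoid dehydrogenase inhibitor

The source may hold more compounds than are shown below. What is called first, only, known or untested is meant among the compounds shown, and "the series" means these compounds.

Of the compounds shown here, three with a shared core have been measured in an assay for binding affinity to 17-beta-hydroxysteroid dehydrogenase 14 (Homo sapiens), read by fluorescence, with a stated time of 15 min, in the presence of a further agent that is not named here; a lower number here means a stronger inhibitor, a higher number a weaker inhibitor. Compound 1 `O=C(c1ccc(F)c(O)c1)c1ccc2cc(O)ccc2n1` gives 119 nM, compound 2 `N#Cc1ccc2ccc(C(=O)c3ccc(F)c(O)c3)nc2c1` gives 9 nM, and compound 3 `O=C(c1ccc(F)c(O)c1)c1ccc2ccc(-c3nnn[nH]3)cc2n1` gives 10 nM. Compound 3 thus sits within the scatter of compound 2 and well apart from compound 1. Compound 4 `O=C(c1ccc(F)c(O)c1)c1ccc2ccccc2n1` differs from compound 3 by hydrogen in place of 1H-tetrazol-5-yl on an aromatic carbon. Among the measured compounds shown here, the only measured step, a 1.1-fold higher number from compound 2 to compound 3 (0.05 log units; within the scatter), exchanges one group for another and does not show what a bare hydrogen does there; no measured pair bears directly on the removal. With nothing to anchor it, the expectation for compound 4 is a weakening, estimated as a 10-fold higher number from compound 3 to compound 4 (1.00 log units; beyond the scatter) in this assay. Compound 4 is therefore expected to give about 100 nM, between 25 nM and 400 nM.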

Compound 4, inhibition constant in the 17-beta-hydroxysteroid dehydrogenase 14 assay: 12 nM
The estimate for compound 4 lay 8.3-fold (0.92 log units) above the measured number, and the stated range ends above it.
By their numbers in the 17-beta-hydroxysteroid dehydrogenase 14 assay, from the lowest: compounds 2, 3 and 4 (each within the scatter of the next); then compound 1.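

In the 17-beta-hydroxysteroid dehydrogenase 14 assay, this aromatic carbon carries a bare hydrogen as well as it carries either larger group, a 1.2-fold higher number from compound 3 to compound 4 (0.08 log units; within the scatter) and a 1.3-fold higher number from compound 2 to compound 4 (0.12 log units; within the scatter), whereas hydroxy on the shared core goes with a clearly weaker inhibitor, a 9.9-fold lower number from compound 1 to compound 4 (1.00 log units; beyond the scatter). In a physicochemical assay for solubility, in phosphate buffer, with a stated time of 24 h, at pH 7.4, tested at 200 uM (a lower number here means a less soluble compound, a higher number a more soluble compound), compound 3 gives 50000 nM. In the physicochemical assay compound 4 gives > 200000 nM, which is a limit of the assay and not a number: the limit of > 200000 nM in the physicochemical assay, at which 1 of the 2 values shown sits.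

As far as these compounds go, whether an amine or a carboxylic acid on this carbon would also leave the number within the scatter remains open.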